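The compounds below may be only part of what the source reports. "The series", "measured", "known", "first", "only" and "open" are said of these compounds alone.

Three compounds have been measured in an assay on COS-7 cells for inhibition of patatin-like phospholipase domain-containing protein 2 (Mus musculus); on this read-out lower numbers stand for stronger inhibition and higher numbers for weaker inhibition:

- compound 1, `CCOC(=O)c1cccc(-c2ccc(N(C)C)cc2)c1`, gives 40000 nM
- compound 2, `CCOC(=O)c1cccc(-c2cccs2)c1`, gives 90000 nM
- compound 3, `CCOC(=O)c1cccc(-c2ccc(CN3CCN(C)CC3)o2)c1`, gives 120000 nM

Compound 1 stands lowest of these three numbers in this assay, and each of the other two lies beyond the scatter of it: compound 2 is the nearest, compound 3 the furthest. All three numbers, however, describe weak inhibition, so compound 1 is the least weak of a weak set rather than a strong inhibitor.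

Compound 4, `CCOC(=O)c1cccc(-c2ccc(C(C)=O)cc2)c1`, differs from compound 1 in one place: acetyl in place of dimethylamino on an aromatic carbon. Within the data shown here, no pair of measured compounds shows the effect of this exchange, so the direction of the step is not known from the data. The expected step from compound 1 to compound 4 is a 1.5-fold higher number from compound 1 to compound 4 (0.18 log units; within the scatter), which is to say no change clearly beyond the scatter, with a slight lean towards a higher number. On that basis compound 4 is estimated at 60000 nM in this assay, within a range from 20000 nM to 180000 nM.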

Compound 4, half-maximal inhibitory concentration: 200000 nM
The estimate for compound 4 lay 3.3-fold (0.52 log units) below the measured number; the measured number lies above the stated range.
By their numbers in this assay, from the lowest: compound 1; then compounds 2, 3 and 4 (each within the scatter of the next, the first and the last beyond it).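

In this assay, among these compounds, the exchange of dimethylamino for acetyl gives the first direct reading of one position, the aromatic carbon para to a large group: a 5.0-fold higher number from compound 1 to compound 4 (0.70 log units; beyond the scatter). The two groups have the same counts of heavy atoms and hydrogen-bond acceptors, and neither carries a net charge, so the number at this position can shift beyond the scatter even when those counts stay the same. Nothing measured here explains what in the exchange produces the step.

Among the compounds shown here, with only two groups compared at this position, it remains open whether dimethylamino helps or acetyl hurts. How a plain amino group, a diethylamino group or a carboxylic acid would read here is also unknown, as is whether any group at this position could lift inhibition out of the weak range.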